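Swapping a Triazole Substituent for a Nitrophenyl Group

The source may hold more compounds than are shown below. What is called first, only, known or untested is meant among the compounds shown, and "the series" means these compounds.

Measured compounds:
compound 1 `CCOC(=O)C1=Cc2ccccc2OC1(OCc1cn(CC(=O)NC2CCCCC2)nn1)C(F)(F)F`: 11400 nM
compound 2 `CCOC(=O)C1=Cc2ccccc2OC1(OCc1cc(-c2ccc(Cl)cc2)no1)C(F)(F)F`: 12300 nM
compound 3 `CCOC(=O)C1=Cc2ccccc2OC1(OCc1cc(-c2ccc([N+](=O)[O-])cc2)no1)C(F)(F)F`: a limit, > 150000 nM

In a functional assay on HeLa cells (Homo sapiens) for inhibition, read by MTT assay, with a stated time of 24 h (on this read-out higher numbers stand for weaker inhibition and lower numbers for stronger inhibition), compound 1 gives 11400 nM, the lowest of the two numbers shown. Compound 2 gives 12300 nM, which sits within the scatter of compound 1. For compound 3 this assay reports only a limit, > 150000 nM. Within the data shown here, the single measured step, an at least 12-fold higher number from compound 2 to compound 3 (1.08 log units; beyond the scatter), followed the entry of a nitro group (the limit of > 150000 nM in this assay, at which 1 of the 3 values shown sits).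

Compound 4 `CCOC(=O)C1=Cc2ccccc2OC1(OCc1cn(-c2ccc([N+](=O)[O-])cc2)nn1)C(F)(F)F` differs from compound 1 in one place: 4-nitrophenyl in place of (cyclohexylcarbamoyl)methyl on an aromatic nitrogen. The entering group again carries a nitro group. Because that earlier change gave an at least 12-fold higher number from compound 2 to compound 3 (1.08 log units; beyond the scatter), a clearly weaker result is expected here too. Compound 4 is therefore estimated at 60000 nM, with a range from 15000 nM to 200000 nM. This estimate means a step of a 5.3-fold higher number from compound 1 to compound 4 (0.72 log units; beyond the scatter), and a limit rather than a number is quite possible.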

Compound 4, half-maximal inhibitory concentration: > 150000 nM
Compound 4: a limit, no number (the forecaster's own chance of this, stated with the estimate: 40%); middle value at least 2.5-fold (0.39 log units) from the limit.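

On the aromatic nitrogen of the five-membered ring, putting 4-nitrophenyl in place of (cyclohexylcarbamoyl)methyl gives an at least 13-fold higher number from compound 1 to compound 4 (1.11 log units; beyond the scatter) in this assay, so the result at this position clearly depends on the group it carries. A nitro-bearing aryl group now coincides with a limit, not a number, on two different side chains, compound 3 and compound 4: the limit of > 150000 nM in this assay, at which 2 of the 4 values shown sit.

Still open, from the compounds shown here alone, is whether the nitro group or the loss of (cyclohexylcarbamoyl)methyl matters more here. A plain phenyl or a 4-aminophenyl group on the same nitrogen would help to separate the two.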